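Swapping the acidic ring on a shared core

The compounds below may be only part of what the source reports. "The series", "measured", "known", "first", "only" and "open" are said of these compounds alone.

Compound 1 `CC(C)C(CC1C(=O)NC(=O)N1C)c1ccc(-c2ccc3cccc(F)c3c2)[nH]c1=O`: 65 nM
Compound 2 `CC(C)C(c1ccc(-c2ccc3cccc(F)c3c2)[nH]c1=O)C1SC(=O)NC1=O`: 110 nM

Of the compounds shown here, two sharing the same core have been tested in a functional assay on CHO cells for antagonist activity at prostaglandin E2 receptor EP3 subtype (Homo sapiens), read by cAMP accumulation, with a stated time of 30 min; on this read-out lower numbers stand for stronger inhibition and higher numbers for weaker inhibition. Compound 1 gives 65 nM and compound 2 gives 110 nM. Compound 2 therefore has the higher of the two numbers, but the step of a 1.7-fold higher number from compound 1 to compound 2 (0.23 log units; within the scatter), so the two compounds cannot be told apart on this read-out.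

Compound 3 `C/C(=C1/OC(=O)NC1=O)C(c1ccc(-c2ccc3cccc(F)c3c2)[nH]c1=O)C(C)C` has not yet been measured. It differs from compound 2 in one place: a group of 9 heavy atoms (5 carbon, 1 nitrogen, 3 oxygen; one five-membered non-aromatic ring with 2 hetero atoms) in place of a group of 7 heavy atoms (3 carbon, 1 nitrogen, 2 oxygen, 1 sulfur; one five-membered non-aromatic ring with 2 hetero atoms), on a saturated chain carbon bound to an aromatic carbon and a saturated chain carbon. Among the compounds with values here, the only measured step, a 1.7-fold higher number from compound 1 to compound 2 (0.23 log units; within the scatter), concerns a different replacement at that same position and was itself small. Within the data shown here, no measured step describes the change from compound 2 to compound 3, so the expectation rests on the pattern that exchanging the five-membered ring here left the number nearly unchanged.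

Compound 3 is therefore expected to show a 1.4-fold higher number from compound 2 to compound 3 (0.13 log units; within the scatter) in this assay. The estimate for compound 3 is 150 nM, with a range from 50 nM to 500 nM.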

Compound 3, half-maximal inhibitory concentration: 39 nM
The estimate for compound 3 lay 3.8-fold (0.59 log units) above the measured number; the whole stated range lies above it.
By their numbers in this assay, from the lowest: compounds 3, 1 and 2 (each within the scatter of the next, the first and the last beyond it).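

In this assay, this place on the saturated chain carbon proves sensitive to the exact ring group: a 2.8-fold lower number from compound 2 to compound 3 (0.45 log units; beyond the scatter), whereas the earlier exchange stayed within the scatter. The entering and leaving groups each hold one five-membered non-aromatic ring with the same counts of hydrogen-bond donors and acceptors, so those shared counts do not fix the number. Against the other partner the result is not separated, a 1.7-fold lower number from compound 1 to compound 3 (0.22 log units; within the scatter), and no supporting evidence is available to explain either step.

On these data alone, whether a carboxylic acid or an amine could stand on this carbon in place of these rings remains open. Also open, as far as these compounds go, is how much of the gain belongs to oxygen replacing sulfur and how much to the added carbons and double bond, since these arrive together in one group.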